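Swapping methyl for nitro on the sulfonyl aryl group

The compounds below may be only part of what the source reports. "The series", "measured", "known", "first", "only" and "open" are said of these compounds alone.

Values measured in a functional assay on SMMC-7721 cells (Homo sapiens) for cytotoxicity, read by MTT assay, with a stated time of 24 h; on this read-out higher numbers stand for weaker inhibition and lower numbers for stronger inhibition:
- Compound 1 `O=C1/C(=C/c2ccncc2)CN(S(=O)(=O)c2ccc([N+](=O)[O-])cc2)C/C1=C\c1ccccc1F`: 15800 nM
- Compound 2 `O=C1/C(=C/c2ccncc2)CNC/C1=C\c1ccccc1C(F)(F)F`: 4500 nM
- Compound 3 `Cc1ccc(S(=O)(=O)N2C/C(=C\c3ccncc3)C(=O)/C(=C/c3ccccc3C(F)(F)F)C2)cc1`: 5590 nM

In this assay compound 3 gives 5590 nM. That lies within the scatter of compound 2 at 4500 nM, while compound 1 at 15800 nM reads clearly higher than both.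

Compound 4 `O=C1/C(=C/c2ccncc2)CN(S(=O)(=O)c2ccc([N+](=O)[O-])cc2)C/C1=C\c1ccccc1C(F)(F)F` differs from compound 3 in one group: nitro in place of methyl on an aromatic carbon. This places nitro in place of methyl on an aromatic carbon, para to a large group, turning 4-methylphenyl to 4-nitrophenyl.

Among the compounds with values here, no measured step makes this exact change. The nearest, a 1.2-fold higher number from compound 2 to compound 3 (0.09 log units; within the scatter), adds the (4-methylphenyl)sulfonyl group and stays within the scatter. Compound 1 at 15800 nM carries the (4-nitrophenyl)sulfonyl group but has a different aryl group on the shared core, so it leans the expectation only mildly upward.

A small step is therefore expected, with no shift beyond the scatter: a 1.3-fold higher number from compound 3 to compound 4 (0.13 log units; within the scatter).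

For compound 4 the estimated value is 7500 nM, with an expected range of 2800 nM to 20000 nM.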

Compound 4, half-maximal inhibitory concentration: > 20000 nM
Compound 4: only a limit was reported; the forecaster's own chance of this, stated with the estimate: 3%; middle value at least 2.6-fold (0.42 log units) from the limit.
By their numbers in this assay, from the lowest: compounds 2 and 3 (each within the scatter of the next); then compound 1. At a limit, above all of these: compound 4.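

In this assay compound 4 gives > 20000 nM, which is a limit of the assay and not a number. On the sulfonyl aryl ring, the change of group at this position, para to a large group, does move the read-out, with an at least 3.5-fold higher number from compound 3 to compound 4 (0.55 log units; beyond the scatter), and placing the (4-nitrophenyl)sulfonyl group on the ring nitrogen gives an at least 4.4-fold higher number from compound 2 to compound 4 (0.64 log units; beyond the scatter), whereas the (4-methylphenyl)sulfonyl group had stayed within the scatter of the unsubstituted amine. The exchange on the other aryl group remains unsized, with an at least 1.2-fold higher number from compound 1 to compound 4 (0.10 log units; that floor lies within the scatter), so this floor does not separate the two compounds.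

The compounds shown leave open how far the read-out of compound 4 actually lies from those of its neighbours. They also leave open how an amine or a methoxy group at this position would read.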